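Halogen swap on the benzamide ring of a thieno series

The source may report more compounds than this note shows. Statements on the series, on what has been measured and on what is new or still open speak of the compounds shown alone.

The series rests on a shared core in which one ring carries a thiourea-linked aniline and another carries a benzamide. Compound 1 `NC(=O)c1c(NC(=O)c2ccccc2Cl)sc2c1CCN(C(=S)Nc1ccccc1Br)C2` bears bromo on the aniline ring and chloro on the benzamide ring; in a functional assay on HL-60 cells (Homo sapiens) for antiproliferative activity, with a stated time of 24 h (a lower number here means a stronger inhibitor, a higher number a weaker inhibitor), compound 1 gives 9090 nM. Compound 2 `NC(=O)c1c(NC(=O)c2ccccc2Cl)sc2c1CCN(C(=S)Nc1ccccc1I)C2` carries iodo in place of bromo on the aniline ring (iodo in place of bromo on an aromatic carbon), and in this assay compound 2 gives 4430 nM. The resulting step is a 2.1-fold lower number from compound 1 to compound 2 (0.31 log units; beyond the scatter).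

Compound 3 `NC(=O)c1c(NC(=O)c2ccccc2Br)sc2c1CCN(C(=S)Nc1ccccc1Cl)C2` is built from the same atoms as compound 1, joined differently, with chloro on the aniline ring and bromo on the benzamide ring; how the two cores differ is not broken down here. In this assay compound 3 gives 14600 nM, a number within the scatter of compound 1 but beyond it relative to compound 2.

Compound 4 `NC(=O)c1c(NC(=O)c2ccccc2I)sc2c1CCN(C(=S)Nc1ccccc1Cl)C2`, not yet measured, differs from compound 3 by iodo in place of bromo on an aromatic carbon. The place reads the same as for the earlier pair, on an aromatic carbon of a six-membered aromatic ring of carbon only, ortho to a large group, although the ring now sits on the carbonyl rather than the thiourea side, so this is the same kind of change. The expected step is a 1.7-fold lower number from compound 3 to compound 4 (0.23 log units; within the scatter), a step of similar sign to a 2.1-fold lower number from compound 1 to compound 2 (0.31 log units; beyond the scatter) but drawn with wide bounds because it rests on that single measured pair. Compound 4 is therefore estimated at 8500 nM, with a range from 4000 nM to 18000 nM.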

Compound 4, half-maximal inhibitory concentration: 8560 nM
Estimate against measurement, compound 4: 1.0-fold (0.00 log units) below, within the range that was stated.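

In this assay, iodo in place of bromo on an aromatic carbon gives a 1.7-fold lower number from compound 3 to compound 4 (0.23 log units; within the scatter), and the two steps for this change do not differ: the same change on two cores in this assay, a 2.1-fold lower number (0.31 log units; beyond the scatter) from compound 1 to compound 2 and a 1.7-fold lower number (0.23 log units; within the scatter) from compound 3 to compound 4, 1.2-fold (0.08 log units) apart, within the scatter of two such steps. The change therefore reads as transferable between these two cores, in the sense that no difference in step size can be detected, although the step on the core of compound 3 stays within the scatter on its own and so offers only weak support. With just two pairs, and the swap on the aniline ring in one and on the benzamide ring in the other, this does not establish a rule for the series, nor does it separate the influence of the core from that of the ring carrying the halogen.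

Still open, as far as these compounds go, is how the same place responds to groups other than halogens, such as a methoxy group, an amine or a carboxylic acid, and whether any of these would keep the same step on both cores. Also open, from the compounds shown here alone, is how a compound with iodo on both the aniline and the benzamide ring would read in this assay.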